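The compounds below may be only part of what the source reports. "The series", "measured", "known", "first", "only" and "open" are said of these compounds alone.

Compound 1 `c1ccc(N2N=NCC2c2ccncc2)cc1` gives 165 mg/kg in a functional assay on the whole organism with Mus musculus as the target, in the maximal electroshock model; a higher number here means that more compound is needed for the effect, a lower number that less compound is needed. Compound 2 `FC(F)(F)c1ccc(N2N=NCC2c2ccncc2)cc1` gives 689 mg/kg in this assay. Compound 3 `c1ccc(-n2nncc2-c2cccnc2)cc1` gives 76.4 mg/kg in this assay.

Compound 2 differs from compound 1 by trifluoromethyl in place of hydrogen on an aromatic carbon. That change brought a 4.2-fold higher number from compound 1 to compound 2 (0.62 log units; beyond the scatter). Compound 3 has a different core; how its core differs from the core of compound 1 is not broken down here. In this assay compound 3 gives the lowest number of the three.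

Among the compounds with values here, compound 4 `FC(F)(F)c1ccc(-n2nncc2-c2cccnc2)cc1` is the still unmeasured partner of compound 3, differing from it by trifluoromethyl in place of hydrogen on an aromatic carbon, the same change as the one from compound 1 to compound 2. The step in this assay expected for compound 4 is a 4.2-fold higher number from compound 3 to compound 4 (0.62 log units; beyond the scatter), resting on a 4.2-fold higher number from compound 1 to compound 2 (0.62 log units; beyond the scatter). For compound 4 the estimate is 320 mg/kg, expected to lie between 150 mg/kg and 700 mg/kg.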

Compound 4, dose for half-maximal effect: 92.3 mg/kg
Estimate against measurement, compound 4: 3.5-fold (0.54 log units) above, outside the stated range (below it).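

In this assay, trifluoromethyl in place of hydrogen on an aromatic carbon brought a 1.2-fold higher number from compound 3 to compound 4 (0.08 log units; within the scatter), so on this core the change makes no clear difference. The step seen on the core of compound 1 therefore did not carry over to the core of compound 3: the same change on two cores in this assay, a 4.2-fold higher number (0.62 log units; beyond the scatter) from compound 1 to compound 2 and a 1.2-fold higher number (0.08 log units; within the scatter) from compound 3 to compound 4, 3.5-fold (0.54 log units) apart, beyond the scatter of two such steps. Within the data shown here, with only two pairs, this shows that the step cannot be assumed to transfer between these two cores, but not which difference between the cores matters or what the change would do on a further core.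

Still open, going by these compounds, is whether another group in the same place, such as chlorine, a methoxy group or an amine, would give matching steps on both cores.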